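The compounds below may be only part of what the source reports. "The series", "measured", "known", "first", "only" and "open" are said of these compounds alone.

Measured in a functional assay on A2780 cells (Homo sapiens) for antiproliferative activity, read by CellTiter-Glo, with a stated time of 72 h; a lower number here means a stronger inhibitor, a higher number a weaker inhibitor:
- Compound 1 `O=C(Nc1ccc(CN2Cc3ccccc3C2=O)cc1)N1CCC(c2cccnc2)CC1`: 1030 nM
- Compound 2 `C[C@@H](c1ccc(NC(=O)N2CC(c3cccnc3)C2)cc1)N1Cc2ccccc2C1=O`: 1.5 nM
- Compound 3 `C[C@H](NC(=O)c1cccc(F)c1)c1ccc(NC(=O)N2CC(c3cccnc3)C2)cc1`: 2.3 nM

Compound 3, at 2.3 nM, stands within the scatter of compound 2, at 1.5 nM. Both values lie far under that of compound 1, at 1030 nM.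

Compound 4 `C[C@H](NC(=O)c1ncccn1)c1ccc(NC(=O)N2CC(c3cccnc3)C2)cc1` carries pyrimidin-2-yl in place of 3-fluorophenyl on a carbonyl carbon. Within the data shown here, one measured step bears on this change: a 1.5-fold higher number from compound 2 to compound 3 (0.19 log units; within the scatter). That step exchanged a whole group on a saturated chain carbon and stayed within the scatter. Among the measured compounds shown here, no measured pair changes the group on the carbonyl carbon alone, so this evidence is only indirect.

In this assay, a small step is therefore expected, leaning towards a higher number and most likely not beyond the scatter. The expected step is a 1.7-fold higher number from compound 3 to compound 4 (0.24 log units; within the scatter). For compound 4 the estimated value is 4 nM, with an expected range from 1.2 nM to 14 nM.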

Compound 4, half-maximal inhibitory concentration: 36 nM
The estimate for compound 4 lay 9.0-fold (0.95 log units) below the measured number, and the stated range ends below it.
By their numbers in this assay, from the lowest: compounds 2 and 3 (each within the scatter of the next); then compound 4; then compound 1.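

In this assay, the group on the carbonyl carbon turns out to matter: with pyrimidin-2-yl in place of 3-fluorophenyl there is a 16-fold higher number from compound 3 to compound 4 (1.19 log units; beyond the scatter), the first shown step in which this group alone changes. The earlier exchange on the saturated chain carbon, a 1.5-fold higher number from compound 2 to compound 3 (0.19 log units; within the scatter), stayed within the scatter, whereas a 24-fold higher number from compound 2 to compound 4 (1.38 log units; beyond the scatter) shows that not every group at that place leaves the number unchanged. Nothing available gives a reason for this loss of activity.

With only 3-fluorophenyl and pyrimidin-2-yl shown on this carbonyl carbon, the step cannot be assigned to the two ring nitrogens entering or to the fluorine leaving. Going by these compounds, how an unsubstituted phenyl or a pyridin-2-yl ring would read there remains open, and so does the effect of a dimethylamino group in that place.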